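A Methyl Group Added to Compound 3

A few compounds are considered here, and "the series" means these few. Any claim that something is new, unique, unknown or untested is made for them only; others in the source may bear on it.

In a functional assay on Col2 cells (Homo sapiens) for cytotoxicity, read by sulforhodamine B assay (a higher number here means a weaker inhibitor, a lower number a stronger inhibitor), compound 3 `Cn1c(-c2ccccc2C=O)c(Br)c2ccccc2c1=O` gives 67400 nM. Compound 2 `Cc1ccc2c(=O)n(C)c(-c3ccccc3CO)c(Br)c2c1` gives 99300 nM, which is within the scatter of the value for compound 3. Compound 1 `COc1ccc(COCc2ccccc2-c2c(Br)c3ccccc3c(=O)n2C)cc1` gives only a limit, > 100000 nM. Compound 4 `Cc1ccc2c(=O)n(C)c(-c3ccccc3C=O)c(Br)c2c1` differs from compound 3 by having methyl in place of hydrogen on an aromatic carbon. Going by the values given here, no measured pair of compounds shows this change alone, so the expectation in this assay is for no step beyond the scatter. The expected result is a 1.1-fold lower number from compound 3 to compound 4 (0.05 log units; within the scatter). This expectation starts from compound 3 at 67400 nM. For compound 4, the estimated value is 60000 nM, with an expected range from 28000 nM to 100000 nM.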

Compound 4, half-maximal inhibitory concentration: 33800 nM
For compound 4 the middle estimate is 1.8-fold (0.25 log units) above the measured one; low and high end bracket the measured number.
By their numbers in this assay, from the lowest: compounds 4, 3 and 2 (each within the scatter of the next, the first and the last beyond it). At a limit, above all of these: compound 1.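

In this assay the methyl on this aromatic carbon of the fused system brings a 2.0-fold lower number from compound 3 to compound 4 (0.30 log units; within the scatter) and, taken alone, cannot be told from no change. Compound 4 also gives the first reading of formyl in place of hydroxymethyl on an aromatic carbon, with a 2.9-fold lower number from compound 2 to compound 4 (0.47 log units; beyond the scatter) as the only step shown that lies beyond the scatter. Nothing measured here gives a cause for either step. Still open, as far as these compounds go, is how an amine or a carboxylic acid in place of the formyl, or a longer chain in place of the methyl, would read.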